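Cytotoxicity notes on the biaryl amide series

A few compounds are considered here, and "the series" means these few. Any claim that something is new, unique, unknown or untested is made for them only; others in the source may bear on it.

Compound 1 `CCOc1cccc(-c2ccc(C(=O)N(Cc3cccc(OCCCCCC(=O)O)c3)C(C)C)cc2)c1` and compound 2 `CCOC(=O)CCCCCOc1cccc(CN(C(=O)c2ccc(-c3cccc(C(C)=O)c3)cc2)C(C)C)c1` share the same amide core and differ only in the outer aryl group and the chain end; compound 3 `CCOC(=O)CCCCCOc1cccc(CN(C(=O)c2ccc(-c3cc(OC)ccc3F)cc2)C(C)C)c1` remains to be measured. In an ADME assay on HEK293 cells (Homo sapiens) for cytotoxicity, read by CellTiter-Glo and resazurin assay, with a stated time of 72 h (a higher number here means that more compound is needed for the effect, a lower number that less compound is needed), compound 1 gives only a limit, > 20800 nM. Compound 2 also gives only a limit in this assay, > 26000 nM. Within the data shown here, compound 2 therefore stands at a limit, and the one other value known in this assay is a limit as well, so the two values show only that neither compound reaches the window of this assay (the limit of > 20800 nM in this assay, at which 1 of the 2 values shown sits; (the limit of > 26000 nM in this assay, at which 1 of the 2 values shown sits)). Compound 3 differs from compound 2 in one place: 2-fluoro-5-methoxyphenyl in place of 3-acetylphenyl on an aromatic carbon. Among the measured compounds shown here, with no measured step, the step of a number no higher from compound 2 to compound 3 (the limit leaves the size open) is expected to be none beyond the scatter. For compound 3 the estimate in this assay is 26000 nM, with a range from 12000 nM to 60000 nM, and a limit rather than a number is the expected outcome.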

Compound 3, half-maximal effective concentration: > 26000 nM
Compound 3: no number, only a limit (the forecaster's own chance of this, stated with the estimate: 85%); the middle value sits exactly at the limit.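

Compound 2 and compound 3 both give only a limit in this assay, so no step can be read between them for 2-fluoro-5-methoxyphenyl in place of 3-acetylphenyl. The compounds shown leave open at what concentration any of them would reach the effect in this assay.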